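The compounds below may be only part of what the source reports. "The series", "measured", "known", "first", "only" and "open" are said of these compounds alone.

In a functional assay on HepG2 cells (Homo sapiens) for antiproliferative activity, read by MTT assay, with a stated time of 72 h (a lower number here means a stronger inhibitor, a higher number a weaker inhibitor), compound 1 `O=C1O/C(=C\Cn2cnc3c(F)nc(F)c(Cl)c32)C(OCc2ccccc2)=C1OCc1ccccc1` reads > 100000 nM, which is a limit of the assay and not a number. Compound 2 `O=C1NC(O)(CCn2cnc3cc[nH]c3c2=O)C(OCc2ccccc2)=C1OCc1ccccc1` reads > 100000 nM, also a limit, and so stands at the limit of > 100000 nM in this assay, at which 2 of the 3 values shown sit. Compound 3 `O=C1O/C(=C\Cn2cnc3cncc(Br)c32)C(OCc2ccccc2)=C1OCc1ccccc1` gives 46900 nM. Compound 4 `O=C1NC(O)(CCn2cnc3cncc(Br)c32)C(OCc2ccccc2)=C1OCc1ccccc1` differs from compound 2 by a group of 10 heavy atoms (6 carbon, 3 nitrogen, 1 bromine; one five-membered aromatic ring with 2 hetero atoms, one six-membered aromatic ring with 1 hetero atom) in place of a group of 10 heavy atoms (6 carbon, 3 nitrogen, 1 oxygen; one five-membered aromatic ring with 1 hetero atom, one six-membered aromatic ring with 2 hetero atoms), on a saturated chain carbon, two bonds along the chain from a saturated ring carbon. Among the compounds with values here, the entering group is the one compound 3 already carries, on a different chain. Within the data shown here, the only measured step that bears on this change is an at least 2.1-fold lower number from compound 1 to compound 3 (0.32 log units; beyond the scatter), and it rests on a limit at one end. A change in the same direction and of similar size is therefore expected in this assay, an estimated at least 1.6-fold lower number from compound 2 to compound 4 (0.22 log units; that floor lies within the scatter). Compound 4 is estimated at 60000 nM, with an expected range of 25000 nM to 140000 nM.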

Compound 4, half-maximal inhibitory concentration: 66500 nM
Beside the measured number, compound 4's estimate is 1.1-fold (0.04 log units) below it, and the stated range covers the measured number.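

Compound 2 reads a limit of the assay and not a number: the limit of > 100000 nM in this assay, at which 2 of the 4 values shown sit.

In this assay, the bromine-bearing group gives compound 4 a measured number on this chain, so the change can now be followed on a second core, as an at least 1.5-fold lower number from compound 2 to compound 4 (0.17 log units; that floor lies within the scatter), though that floor lies within the scatter. Both compounds shown with this group, compound 3 and compound 4, thus read as numbers.

From the compounds shown here alone, the true size of the step stays open, with one end at a limit. The compounds shown also leave open how an amine or a longer chain would read here.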